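The compounds below may be only part of what the source reports. "The series", "measured", "known", "first", "only" and "open" are said of these compounds alone.

Measured so far in a functional assay on SK-MEL-2 cells (Homo sapiens) for cytotoxicity, read by sulforhodamine B assay, with a stated time of 2 days, tested at 100 uM; on this read-out higher numbers stand for more inhibition at the one concentration tested (going by the name of the read-out) and lower numbers for less inhibition:
compound 1 `CCCc1n[nH]c2c(=O)n(NC(=O)c3ccccc3)c(-c3cccc([N+](=O)[O-])c3)nc12` gives 22.9%
compound 2 `O=C(Nn1c(-c2cccc([N+](=O)[O-])c2)nc2c(-c3cccc(Cl)c3)n[nH]c2c1=O)c1ccccc1` gives 78.2%
compound 3 `COc1cccc(-c2nc3c(-c4cccc(Cl)c4)n[nH]c3c(=O)n2NC(=O)c2ccccc2)c1` gives 81.9%

Compound 2 stands second highest of the three numbers. Its nearest neighbour is compound 3, within the scatter; its furthest is compound 1, beyond the scatter. The step of a number 55.3 percentage points higher from compound 1 to compound 2 (beyond the scatter) is the one large movement in the series. The step of a number 3.7 percentage points higher from compound 2 to compound 3 (within the scatter) shows that exchanging the group on the other aryl ring leaves the number where it was.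

Compound 4 `O=C(Nn1c(-c2cccc([N+](=O)[O-])c2)nc2c(-c3ccc(F)cc3)n[nH]c2c1=O)c1ccccc1` is not yet measured. It differs from compound 2 in one place: 4-fluorophenyl in place of 3-chlorophenyl on an aromatic carbon. Among the measured compounds shown here, no measured step exchanges one aryl ring for another on that carbon. For the measured compounds named here, the only step touching that position, a number 55.3 percentage points higher from compound 1 to compound 2 (beyond the scatter), replaces a propyl chain by an aryl ring and so is of a different kind; compound 4 keeps an aryl ring there, and the gain seen in that step is expected to be kept. The swap at the remaining aryl ring, a number 3.7 percentage points higher from compound 2 to compound 3 (within the scatter), was within the scatter, which supports expecting little movement from a change of halogen and of its position on a ring. The expected step is a number 6.2 percentage points lower from compound 2 to compound 4 (within the scatter), not beyond the scatter. Going by the values given here, the estimate for compound 4 is 72%, in a range from 48% to 90%, widened since no direct precedent exists.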

Compound 4, a percentage reported as inhibition, at one concentration (the size of the read-out at that concentration, not a potency): 88.5%
The estimate for compound 4 lay 16.5 percentage points below the measured number; the measured number falls inside the stated range.
By their numbers in this assay, from the lowest: compound 1; then compounds 2, 3 and 4 (each within the scatter of the next, the first and the last beyond it).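

In this assay, among the compounds shown here, this aromatic carbon of the five-membered aromatic ring now proves sensitive to an exchange of one aryl ring for another: the step of a number 10.3 percentage points higher from compound 2 to compound 4 (beyond the scatter) is modest, so the choice between 3-chlorophenyl and 4-fluorophenyl is not neutral here, whereas the one exchange read at the other aryl ring stayed within the scatter. The step of a number 65.6 percentage points higher from compound 1 to compound 4 (beyond the scatter) shows that the large gain over propyl is not confined to 3-chlorophenyl and holds for both aryl rings shown at this carbon. No available evidence accounts for either step.

The exchange alters the halogen and its place on the ring together, so the two contributions remain unseparated; 4-chlorophenyl and 3-fluorophenyl at this carbon would pull them apart. On these data alone, whether the gain requires an aromatic ring at all also stays open, and a cyclohexyl ring or a longer chain at this carbon would address that, while pairing 4-fluorophenyl with the methoxy-bearing aryl ring would test whether the two positions act independently.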